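The compounds below may be only part of what the source reports. "The series", "measured", "known", "first", "only" and "open" are said of these compounds alone.

Compound 1 `OC1CCN(Cc2ccccc2)CC1N1CCN(c2ccccc2)CC1` in an assay on PC-12 cells for displacement of a labelled ligand from vesicular acetylcholine transporter (Homo sapiens); a higher number here means a weaker inhibitor, a lower number a stronger inhibitor: compound 1 gives > 100 nM, which is a limit of the assay and not a number.
Compound 2 `OC1CCN(Cc2ccc(Br)cc2)CC1N1CCN(c2ccccc2)CC1`: compound 2 gives > 100 nM, again a limit.
Compound 3 `C=CCN1CCC(O)C(N2CCN(c3ccccc3)CC2)C1`: compound 3 gives > 100 nM, again a limit.

Compound 3 therefore stands only at a limit in this assay. All three members of the series sit together at the limit of > 100 nM in this assay, at which 3 of the 3 values shown sit. The step to compound 4 `C/C=C/CN1CCC(O)C(N2CCN(c3ccccc3)CC2)C1` is prop-1-en-1-yl in place of vinyl on a saturated chain carbon bound to an amine nitrogen in a ring. Three measured steps could bear on a change at this position: a step that the two limits leave unreadable from compound 1 to compound 3 and a step that the two limits leave unreadable from compound 2 to compound 3 alter the same saturated chain carbon, and a step that the two limits leave unreadable from compound 1 to compound 2 touches a distant aromatic carbon, but none of them is readable in size, as both ends of each sit at the limit. Going by the values given here, no measured step thus gives a size to expect for compound 4 in this assay; the only indication is that every change so far has left the series at the limit. Compound 4 is expected to give 300 nM, with a range from 100 nM to 3000 nM, most probably again reported as a limit. The step this estimate means, a step that the limit leaves unreadable from compound 3 to compound 4, is expected to be undetermined in direction and not separable from the scatter.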

Compound 4, half-maximal inhibitory concentration: > 100 nM
Compound 4: a limit, no number; the forecaster's own chance of this, stated with the estimate: 80%; the middle value is on the limit's open side.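

The steps joining compound 4 to compound 1, compound 2 and compound 3 cannot be read in size, since each end is a limit and not a number: the limit of > 100 nM in this assay, at which 4 of the 4 values shown sit.

The compounds shown leave open whether but-2-en-1-yl in place of allyl, or any other change here, shifts the result in this assay, and in which direction.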